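Chloro on a Pendant Phenyl in Two Related Cores

This account rests on a few compounds, and the source may have more. Where it says the series, first, only, none or still open, it means among the compounds named here.

Measured so far:
compound 1 `N#Cc1c(-c2nnc(-c3nn(-c4ccccc4)c(-c4ccccc4)c3C#N)c3nn(-c4ccccc4)cc23)nn(-c2ccccc2)c1-c1ccccc1`: > 100000 nM
compound 2 `N#Cc1c(-c2nnc(-c3nn(-c4ccccc4)c(-c4ccccc4)c3C#N)c3nn(-c4ccc(Cl)cc4)cc23)nn(-c2ccccc2)c1-c1ccccc1`: 9200 nM
compound 3 `N#Cc1c(-c2nnc(-c3ccccc3)c3nn(-c4ccccc4)cc23)nn(-c2ccccc2)c1-c1ccccc1`: 31800 nM

Compound 1 was tested in a functional assay on MDA-MB-435 cells (Homo sapiens) for inhibition, read by sulforhodamine B assay, with a stated time of 48 h (on this read-out lower numbers stand for stronger inhibition of growth and higher numbers for weaker inhibition of growth), and gave only a limit, (the limit of > 100000 nM in this assay, at which 1 of the 3 values shown sits), not a number. Compound 2 differs from it by chloro in place of hydrogen on an aromatic carbon, and this change gave an at least 10-fold lower number from compound 1 to compound 2 (1.03 log units; beyond the scatter). Compound 3 has a different core; the difference between the two cores is not broken down here. In this assay compound 3 gives 31800 nM, the highest number among the measured compounds. Compound 4 `N#Cc1c(-c2nnc(-c3ccccc3)c3nn(-c4ccc(Cl)cc4)cc23)nn(-c2ccccc2)c1-c1ccccc1` is not yet measured; it differs from compound 3 by chloro in place of hydrogen on an aromatic carbon, the same change as that from compound 1 to compound 2. Because that earlier step was an at least 10-fold lower number from compound 1 to compound 2 (1.03 log units; beyond the scatter), a step in the same direction is expected here, a 4.0-fold lower number from compound 3 to compound 4 (0.60 log units; beyond the scatter), though judged more cautiously since the core differs. Compound 4 is therefore estimated at 8000 nM, between 2000 nM and 25000 nM.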

Compound 4, concentration for 50% growth inhibition: 23800 nM
Estimate against measurement, compound 4: 3.0-fold (0.47 log units) below, within the range that was stated.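

In this assay, going by these compounds alone, replacing phenyl with 4-chlorophenyl gives a 1.3-fold lower number from compound 3 to compound 4 (0.13 log units; within the scatter), so on this core the chloro produces no step that stands clear of the scatter. The size of the change therefore does not carry over from the core of compound 1 to the core of compound 3: the same change on two cores in this assay, an at least 10-fold lower number (1.03 log units; beyond the scatter) from compound 1 to compound 2 and a 1.3-fold lower number (0.13 log units; within the scatter) from compound 3 to compound 4, at least 8.1-fold (0.91 log units) apart, beyond the scatter of two such steps. Compound 1 gave only a limit, > 100000 nM, not a number, and these two pairs do not show which part of the cores sets their steps apart.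

Still open, as far as these compounds go, is how other groups in the same place, such as fluoro, methoxy or an amine, would behave. From the compounds shown here alone, it is also open whether any of them would differ between the two cores as chloro does.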